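The source may hold more compounds than are shown below. What is called first, only, known or untested is meant among the compounds shown, and "the series" means these compounds.

This account follows a single measurement, an ADME assay on J774 cells (Mus musculus) for cytotoxicity, read by MTT assay, with a stated time of 48 h, tested at 100 ug/mL (on this read-out lower numbers stand for a stronger effect and higher numbers for a weaker effect at the one concentration tested), across three compounds that share one core and differ only in one substituent on the benzylidene ring. Compound 1 `O=C(N/N=C/c1ccccc1)c1cnccn1` carries hydrogen there and gives 75%. Compound 2 `O=C(N/N=C/c1ccc(Br)cc1)c1cnccn1` carries bromo and gives 100%. Compound 3 `O=C(N/N=C/c1cccc(O)c1)c1cnccn1` carries hydroxy and gives 100%.

On these numbers compound 2 stands level with compound 3 at the digits shown, the two together being the highest of the three, while compound 1 sits furthest from compound 2 with a lower number. The two measured steps are a number 25 percentage points higher from compound 1 to compound 2 (beyond the scatter) and a number 25 percentage points higher from compound 1 to compound 3 (beyond the scatter), both moving in the same direction and both beyond the scatter.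

Compound 4 `N#Cc1ccc(/C=N/NC(=O)c2cnccn2)cc1` is not yet measured. Its difference from compound 2 is cyano in place of bromo on an aromatic carbon, on an aromatic carbon of a six-membered aromatic ring of carbon only, para to a large group. Within the data shown here, no measured step swaps one substituent for another at this place; both known steps only add a group where hydrogen stood. Since each such addition gave the same high number, the expectation for compound 4 is that it stays near compound 2, with a number 5 percentage points lower from compound 2 to compound 4 (within the scatter) expected to lie within the scatter. Compound 4 is therefore estimated at 95%, between 78% and 100%.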

Compound 4, a percentage reported as activity, at one concentration (the size of the read-out at that concentration, not a potency): 100%
Beside the measured number, compound 4's estimate is 5 percentage points below it, within the range that was stated.
By their numbers in this assay, from the lowest: compound 1; then compounds 2, 3 and 4 (each within the scatter of the next).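

In this assay, among these compounds, this is the first direct exchange of one substituent for another at this place, rather than the addition of a group where hydrogen stood, and it gives no change at the digits printed from compound 2 to compound 4 (within the scatter). The read-out therefore does not separate the cyano group, with its triple bond and its hydrogen-bond acceptor, from the single bromine atom it replaces, while the comparison with hydrogen gives a number 25 percentage points higher from compound 1 to compound 4 (beyond the scatter), the same size as a number 25 percentage points higher from compound 1 to compound 2 (beyond the scatter), so that at this place both groups stand apart from hydrogen by the same printed amount. No measurement is available that would explain why these two different groups read alike or why either differs from hydrogen.

From the compounds shown here alone, whether an amine, a carboxylic acid or a methoxy group at this same place would stay level with compound 2 and compound 4 remains open. Also open is whether any group on this ring would move the number the other way from compound 1, which gives 75% in this assay, since every substituent shown so far has moved it in one direction only.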